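A few compounds are considered here, and "the series" means these few. Any claim that something is new, unique, unknown or untested is made for them only; others in the source may bear on it.

In a functional assay on NCI-H460 cells (Homo sapiens) for cytotoxicity, read by sulforhodamine B assay, with a stated time of 3 days (a lower number here means a stronger inhibitor, a higher number a weaker inhibitor), compound 2 `OCc1cn(Cc2ccc(Cl)cc2)c2ccccc12` gives 16 nM. Compound 3 `OCc1cn(Cc2ccc(Cl)cc2)c2ccc(F)cc12` gives 30 nM, within the scatter of compound 2, while compound 1 `O=Cc1cn(Cc2ccc(Cl)cc2)c2cc(F)ccc12`, at 120 nM, stands beyond the scatter on the higher side of compound 2. Compound 4 `OCc1cn(Cc2ccc(Cl)cc2)c2cc(F)ccc12` departs from compound 2 by a single change, fluoro in place of hydrogen on an aromatic carbon, meta to a fused ring and para to a fused ring. Within the data shown here, the only measured step of this kind, on a different aromatic carbon, is a 1.9-fold higher number from compound 2 to compound 3 (0.27 log units; within the scatter). A similarly small rise, with no shift beyond the scatter, is therefore expected in this assay. The expected step is a 1.6-fold higher number from compound 2 to compound 4 (0.19 log units; within the scatter). For compound 4 the estimate is 25 nM, with an expected range of 10 nM to 60 nM.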

Compound 4, half-maximal inhibitory concentration: 450 nM
Compound 4: middle estimate off by 18-fold (1.26 log units), on the low side; the measured number lies above the stated range.
By their numbers in this assay, from the lowest: compounds 2 and 3 (each within the scatter of the next); then compound 1; then compound 4.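

In this assay the exchange of hydrogen for fluoro proves sensitive to its place: on the aromatic carbon meta to a fused ring and para to a fused ring it brings a 28-fold higher number from compound 2 to compound 4 (1.45 log units; beyond the scatter), whereas on the other carbon it brings a 1.9-fold higher number from compound 2 to compound 3 (0.27 log units; within the scatter). With fluoro at this place, the group carried on the core also counts, as hydroxymethyl in place of formyl brings a 3.8-fold higher number from compound 1 to compound 4 (0.57 log units; beyond the scatter).

On these data alone, whether chloro or methoxy on this same carbon would give a step like that of fluoro, and how a carboxylic acid in place of the hydroxymethyl would compare, stays open. Nothing available accounts for the size of this step.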